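A few compounds are considered here, and "the series" means these few. Any claim that something is new, unique, unknown or untested is made for them only; others in the source may bear on it.

Measured compounds:
compound 1 `O=C(N/N=C/c1cccc(Cl)c1Cl)Nc1cc2c(Nc3ccc(F)c(Cl)c3)ncnc2cc1O[C@H]1CCOC1`, a functional assay on MCF7 cells (Homo sapiens) for cytotoxicity, read by MTT assay, with a stated time of 72 h; on this read-out higher numbers stand for weaker inhibition and lower numbers for stronger inhibition: "not active" (no number reported)
compound 2 `COc1cc2ncnc(Nc3ccc(F)c(Cl)c3)c2cc1NC(=O)N/N=C/c1cccc(Cl)c1Cl`, this assay: 28700 nM

Two compounds sharing the same core have been run in this assay. Compound 1 `O=C(N/N=C/c1cccc(Cl)c1Cl)Nc1cc2c(Nc3ccc(F)c(Cl)c3)ncnc2cc1O[C@H]1CCOC1` returned "not active" (no number reported), so no number stands for it. For the measured compounds named here, compound 2 `COc1cc2ncnc(Nc3ccc(F)c(Cl)c3)c2cc1NC(=O)N/N=C/c1cccc(Cl)c1Cl` is therefore the only compound with a reported number; in this assay compound 2 gives 28700 nM, a weak result by the scale of the read-out. Going by the values given here, no pair of measured compounds differs in one place, so no measured step is available to calibrate how a single change moves the number.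

Compound 3 `CCN(CC)c1ccc(/C=N/NC(=O)Nc2cc3c(Nc4ccc(F)c(Cl)c4)ncnc3cc2OC)c(O)c1` is the next compound to be measured in this assay. It differs from compound 2 by 4-(diethylamino)-2-hydroxyphenyl in place of 2,3-dichlorophenyl on a carbon with a double bond to nitrogen. Among the compounds with values here, with no measured step as a guide and only the weak result of compound 2 28700 nM as a reference point, he expects the step of a 1.1-fold lower number from compound 2 to compound 3 (0.06 log units; within the scatter) to be no larger than the scatter, in no particular direction. For compound 3 he estimates 25000 nM in this assay, within a range from 8000 nM to 80000 nM.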

Compound 3, half-maximal inhibitory concentration: 27300 nM
Compound 3: middle estimate off by 1.1-fold (0.04 log units), on the low side; measured number inside the range.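

In this assay, for the compounds shown here, putting 4-(diethylamino)-2-hydroxyphenyl in place of 2,3-dichlorophenyl on a carbon with a double bond to nitrogen gives a 1.1-fold lower number from compound 2 to compound 3 (0.02 log units; within the scatter), the first measured step, and it lies within the scatter. The two groups differ clearly in what they contain: the entering group brings nitrogen, oxygen, a hydrogen-bond donor and hydrogen-bond acceptors, while the leaving group has two chlorines and neither donor nor acceptor, yet this one exchange leaves the read-out unresolved from its starting point. No measurement at hand accounts for this result.

Going by these compounds, whether anything placed here can move the number beyond the scatter stays open, since this single step cannot speak for other groups, such as a carboxylic acid or a longer alkyl chain in place of the aromatic ring. On these data alone, compound 1 has no number, so the change that sets it apart from compound 2 cannot be sized, and it remains unknown whether that change would alter the outcome of this exchange.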